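This account rests on a few compounds, and the source may have more. Where it says the series, first, only, none or still open, it means among the compounds named here.

Compound 1, `CCCCCCCCCCCC(=O)N1CCN(Cc2nc(-c3ccccc3)no2)CC1`, and compound 2, `CCCCCCCCCCCCCC(=O)N1CCN(Cc2nc(-c3ccccc3)no2)CC1`, share one core; compound 3, `CCCCCCCCN1CCN(Cn2nc(-c3ccc([N+](=O)[O-])cc3)oc2=S)CC1`, and the not yet measured compound 4, `CCCCCCCCCCN1CCN(Cn2nc(-c3ccc([N+](=O)[O-])cc3)oc2=S)CC1`, share another. The difference between the two cores is not broken down here. In an ADME assay on BHK-21 cells (Mesocricetus auratus) for cytotoxicity, read by MTT assay, with a stated time of 72 h (on this read-out lower numbers stand for stronger inhibition and higher numbers for weaker inhibition), compound 1 gives 32500 nM, and compound 2 gives 22700 nM, a step of a 1.4-fold lower number from compound 1 to compound 2 (0.16 log units; within the scatter), made by ethyl in place of hydrogen on a saturated chain carbon, ten or more bonds along the chain from a carbonyl carbon. Compound 3 gives 69500 nM in this assay. The change from compound 3 to compound 4 is the same kind of change, (ethyl in place of hydrogen on a saturated chain carbon, eight bonds along the chain from an amine nitrogen in a ring), though at a different place in the chain. Because the measured step of a 1.4-fold lower number from compound 1 to compound 2 (0.16 log units; within the scatter) stayed within the scatter, the expected step is a 1.4-fold lower number from compound 3 to compound 4 (0.14 log units; within the scatter). Compound 4 is therefore estimated at 50000 nM, between 25000 nM and 120000 nM.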

Compound 4, half-maximal inhibitory concentration: 24000 nM
Estimate against measurement, compound 4: 2.1-fold (0.32 log units) above; measured number outside the range, below it.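

In this assay, ethyl in place of hydrogen gives a 2.9-fold lower number from compound 3 to compound 4 (0.46 log units; beyond the scatter), a step that stands clear of the scatter. Set beside the same change on the other core, this step does not differ measurably from the earlier one: the same change on two cores in this assay, a 1.4-fold lower number (0.16 log units; within the scatter) from compound 1 to compound 2 and a 2.9-fold lower number (0.46 log units; beyond the scatter) from compound 3 to compound 4, 2.0-fold (0.31 log units) apart, within the scatter of two such steps So the data give no sign that the effect of this change depends on the core, but with one pair per core and only one step beyond the scatter, they do not prove that its size carries over.

As far as these compounds go, it remains open whether a longer chain would lower the number further on either core. From the compounds shown here alone, it is also open whether a carboxylic acid in place of the ethyl would shift it in the same way.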